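The compounds below may be only part of what the source reports. "The series", "measured", "known", "first", "only" and "open" are said of these compounds alone.

Measured so far in a functional assay on MGC-803 cells (Homo sapiens) for inhibition, read by MTT assay, with a stated time of 48 h; a lower number here means a stronger inhibitor, a higher number a weaker inhibitor:
- compound 1 `COc1ccc(-c2coc3cc(OCCCCCBr)ccc3c2=O)cc1`: > 100000 nM
- compound 2 `COc1ccc(-c2coc3cc(OCCCCBr)ccc3c2=O)cc1`: 52700 nM

The entry for compound 1, > 100000 nM, is a limit of the assay and not a number. Among the compounds with values here, that leaves compound 2, at 52700 nM, as the only true number available, so it has no measured neighbour to be ranked against.

The next compound, compound 3 `COc1ccc(-c2coc3cc(OCCBr)ccc3c2=O)cc1`, keeps the shared core and changes only the end of the chain: bromo in place of 2-bromoethyl on a saturated chain carbon, two bonds along the chain from an oxygen on an aromatic ring. In words, this is bromo in place of 2-bromoethyl on a saturated chain carbon, two bonds along the chain from an oxygen on an aromatic ring. Put another way, 4-bromobutoxy becomes 2-bromoethoxy.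

Within the data shown here, one measured step bears on this, a smaller change of the same chain: an at least 1.8-fold lower number from compound 1 to compound 2 (0.27 log units; that floor lies within the scatter). As far as these compounds go, that step starts from the limit of > 100000 nM in this assay, at which 1 of the 2 values shown sits, so its true size remains unknown. It offers only a weak lean towards a lower number in this assay, and a modest shift at most is expected.

The step expected is a 1.3-fold lower number from compound 2 to compound 3 (0.12 log units; within the scatter). For compound 3 the estimated value is 40000 nM, with an expected range of 15000 nM to 100000 nM.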

Compound 3, half-maximal inhibitory concentration: > 100000 nM
Compound 3 was reported as a limit; the forecaster's own chance of this, stated with the estimate: 20%; at least 2.5-fold (0.39 log units) between middle value and limit.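

In this assay, cutting 4-bromobutoxy back to 2-bromoethoxy gives an at least 1.8-fold higher number from compound 2 to compound 3 (0.27 log units; that floor lies within the scatter), so the weak lean towards a lower number on the earlier, smaller shortening of this chain does not carry through to the shorter chain. As far as these compounds go, the entry for compound 3 is a limit and not a number, so the real size of this step remains unknown, and the direction rests on a floor that does not clear the usual scatter. The step between compound 1 and compound 3 cannot be read, and compound 2 stays the only compound here with a true number: the limit of > 100000 nM in this assay, at which 2 of the 3 values shown sit.

Still open, from the compounds shown here alone, is whether a 3-bromopropoxy chain would also give a true number, and whether an amine or a carboxylic acid at the end of the chain, in place of the bromo, would change the reading at all. Going by these compounds, how far compound 1 and compound 3 really lie from compound 2 also stays unknown, and a test that reaches further up the concentration scale would be needed to settle it.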